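A hydroxycarbamoyl swap on a compound stuck at a limit

A few compounds are considered here, and "the series" means these few. Any claim that something is new, unique, unknown or untested is made for them only; others in the source may bear on it.

In a functional assay on MDA-MB-231 cells (Homo sapiens) for antiproliferative activity, with a stated time of 72 h (on this read-out lower numbers stand for an effect already at smaller amounts and higher numbers for an effect only at larger amounts of compound), compound 1 (`O=C(O)c1ccc(N(Cc2ccc(C3CCCCC3)cc2)C(=O)[C@H]2CCN2S(=O)(=O)c2c(F)c(F)c(F)c(F)c2F)c(F)c1`) gives > 10000 nM. As far as these compounds go, this is a limit of the assay and not a number, so the true position of compound 1 is unknown. A related structure, compound 2 (`O=C1OCc2cc(N(Cc3ccc(C4CCCCC4)cn3)C(=O)[C@H]3CCN3S(=O)(=O)c3c(F)c(F)c(F)c(F)c3F)ccc21`), does give a real number, 900 nM, but it differs from compound 1 in more than one place. The next structure, compound 3 (`O=C(NO)c1ccc(N(Cc2ccc(C3CCCCC3)cc2)C(=O)[C@H]2CCN2S(=O)(=O)c2c(F)c(F)c(F)c(F)c2F)cc1`), carries 4-(hydroxycarbamoyl)phenyl in place of 4-carboxy-2-fluorophenyl on an amide-type nitrogen. Going by the values given here, no measured pair shows this swap alone, so any expectation is tentative. Since compound 2 reaches 900 nM, a number in that region seems possible for this family. A large step towards smaller amounts is expected, an at least 5.5-fold lower number from compound 1 to compound 3 (0.74 log units; beyond the scatter). For compound 3 the estimated value is 1800 nM, with an expected range from 600 nM to 7000 nM.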

Compound 3, half-maximal effective concentration: 5000 nM
The estimate for compound 3 lay 2.8-fold (0.44 log units) below the measured number; the measured number falls inside the stated range.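

In this assay, compound 3 gives a real number, 5000 nM, so a compound with 4-(hydroxycarbamoyl)phenyl on this amide-type nitrogen can be placed on the scale. The swap from 4-carboxy-2-fluorophenyl gives an at least 2.0-fold lower number from compound 1 to compound 3 (0.30 log units; that floor lies within the scatter). That figure is only a floor and the true size of the step stays unknown, because compound 1 stands at a limit and not at a number: the limit of > 10000 nM in this assay, at which 1 of the 3 values shown sits.

The carboxy group and the ring fluorine both leave in this single swap, and the compounds shown do not tell their contributions apart. They also do not show how a primary amide or a methyl ester would read at the same place on the shared core.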